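Changing One Ring Group on Compound 1

The compounds below may be only part of what the source reports. "The series", "measured", "known", "first", "only" and "open" are said of these compounds alone.

Among the compounds with values here, in a physicochemical assay for solubility, in phosphate buffer, at pH 7.4 (a higher number here means a more soluble compound, a lower number a less soluble compound), compound 1 `CC(=O)N[C@@H]1CCC[C@H](C(=O)Nc2cc(-c3cnc4n3CCCC4)c(Cl)cn2)C1` gives 600000 nM, the highest of the three numbers measured so far. Compound 2 `CC(=O)N[C@@H]1CCC[C@H](C(=O)Nc2cc(-c3cnn4c3CCCCC4)c(Cl)cn2)C1` gives 104000 nM, and compound 3 `CC(=O)N[C@@H]1CCC[C@H](C(=O)Nc2cc(-c3cnn4c3COCC4)c(Cl)cn2)C1` gives 220000 nM. Compound 4 `CC(=O)N[C@@H]1CCC[C@H](C(=O)Nc2cc(-c3cnn4c3CN(C)CC4)c(Cl)cn2)C1` has not yet been measured. Its structure departs from that of compound 1 in one place, on an aromatic carbon of the six-membered aromatic ring: a group of 10 heavy atoms (7 carbon, 3 nitrogen; one five-membered aromatic ring with 2 hetero atoms, one six-membered non-aromatic ring with 2 hetero atoms) in place of a group of 9 heavy atoms (7 carbon, 2 nitrogen; one five-membered aromatic ring with 2 hetero atoms, one six-membered non-aromatic ring with 1 hetero atom), on an aromatic carbon.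

Within the data shown here, two measured steps bear on this change. A larger group brings a 5.8-fold lower number from compound 1 to compound 2 (0.76 log units; beyond the scatter). A group with a six-membered non-aromatic ring with 2 hetero atoms brings a 2.7-fold lower number from compound 1 to compound 3 (0.44 log units; beyond the scatter). Both replacements lowered the number by a modest amount, and the group in compound 4 shares both of these features. Among the measured compounds shown here, no measured compound carries this exact group, so the expectation remains loose. The expected change in this assay is similarly modest and downward, a 2.0-fold lower number from compound 1 to compound 4 (0.30 log units; within the scatter). For compound 4, the estimate is 300000 nM, with an expected range from 110000 nM to 800000 nM.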

Compound 4, solubility: 870000 nM
The estimate for compound 4 lay 2.9-fold (0.46 log units) below the measured number; the whole stated range lies below it.
By their numbers in this assay, from the lowest: compound 2; then compound 3; then compounds 1 and 4 (each within the scatter of the next).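

Compound 4 shows that a larger group on this aromatic carbon need not go with a lower number in this assay: the step is a 1.5-fold higher number from compound 1 to compound 4 (0.16 log units; within the scatter), unlike the fall seen with the seven-membered ring of compound 2. It also shows that the second hetero atom in the six-membered non-aromatic ring matters, as swapping the ring oxygen for a nitrogen carrying a methyl group gives a 4.0-fold higher number from compound 3 to compound 4 (0.60 log units; beyond the scatter). Set against the seven-membered ring group, this new group gives an 8.4-fold higher number from compound 2 to compound 4 (0.92 log units; beyond the scatter), and nothing measured here offers a reason for these steps.

The compounds shown do not separate the ring nitrogen from its methyl group; a ring nitrogen bearing only hydrogen, or an ethyl or acetyl group, would help to tell them apart. From the compounds shown here alone, whether the step holds with another group in place of the chloro group also stays open.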